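Cyclopropyl for pyrrolidin-1-yl: working notes on clearance

The compounds below may be only part of what the source reports. "The series", "measured", "known", "first", "only" and "open" are said of these compounds alone.

Measured values in an ADME assay on microsomes from liver (Rattus norvegicus) for metabolic stability (on this read-out higher numbers stand for fast clearance and lower numbers for slow clearance), are these
compound 1 `CNc1nc(NC)nc(NC2(C#N)CCCCC2)n1` gives 210 mL/min/kg
compound 2 `CNc1nc(NC2(C#N)CCCCCC2)nc(-n2cncn2)n1` gives 276 mL/min/kg
compound 3 `CNc1nc(NC2(C#N)CCCCC2)nc(N2CCCC2)n1` gives > 276 mL/min/kg as a limit

Compound 3 has no number in this assay and stands at the limit of > 276 mL/min/kg in this assay, at which 1 of the 3 values shown sits, as a limit only. Compound 1 with 210 mL/min/kg and compound 2 with 276 mL/min/kg lie within the scatter of each other.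

The change to compound 4 `CNc1nc(NC2(C#N)CCCCC2)nc(C2CC2)n1` is cyclopropyl in place of pyrrolidin-1-yl on an aromatic carbon, counted as cyclopropyl in place of pyrrolidin-1-yl on an aromatic carbon and sitting opposite the ring nitrogen. Among the compounds with values here, the single measured step at this place is an at least 1.3-fold higher number from compound 1 to compound 3 (0.11 log units; that floor lies within the scatter) and it gives a floor, not a size. Within the data shown here, no measured compound carries cyclopropyl at this place, so the direction of the change has little support.

The expected step is an at least 1.3-fold lower number from compound 3 to compound 4 (0.13 log units; that floor lies within the scatter) and a step beyond the scatter is not expected. That expectation rests on compound 1 at 210 mL/min/kg which carries methylamino at this place and no pyrrolidin-1-yl. Compound 4 is estimated at 200 mL/min/kg with an expected range from 110 mL/min/kg to 276 mL/min/kg and may also come back as a limit.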

Compound 4, clearance: 276 mL/min/kg
For compound 4 the middle estimate is 1.4-fold (0.14 log units) below the measured one; the measured number falls inside the stated range.
By their numbers in this assay, from the lowest: compounds 1, 2 and 4 (each within the scatter of the next).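

In this assay, cyclopropyl opposite the ring nitrogen gives this position its first readable step away from methylamino: a 1.3-fold higher number from compound 1 to compound 4 (0.12 log units; within the scatter). Methylamino and cyclopropyl are therefore not told apart at this place by this read-out, although they differ in ring content and in the group carried on the aromatic carbon. Going from pyrrolidin-1-yl to cyclopropyl gives a number no higher from compound 3 to compound 4 (the limit leaves the size open). The size of this step cannot be read, because compound 3 stands only at a limit and not at a number: the limit of > 276 mL/min/kg in this assay, at which 1 of the 4 values shown sits.

The compounds shown leave open whether any group at this place can move clearance beyond the scatter, as a carboxylic acid, a morpholine or a longer alkyl chain might be tested to show, and how far pyrrolidin-1-yl truly sits from cyclopropyl. They also leave open whether this position matters at all for clearance in this assay or whether the shared core, with its nitrile-bearing ring, sets the level seen across compound 1 and compound 4.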